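Amine swap on the acrylamide tail of compound 3

The compounds below may be only part of what the source reports. "The series", "measured", "known", "first", "only" and "open" are said of these compounds alone.

The measured compounds, in a functional assay on PC-3 cells (Homo sapiens) for antiproliferative activity, read by MTT assay, with a stated time of 72 h; a lower number here means a stronger inhibitor, a higher number a weaker inhibitor:
compound 1 `C=CC(=O)Nc1cc2c(N3CCc4ccccc43)ncnc2cc1OC` gives 5940 nM
compound 2 `COc1cc2ncnc(N3CCc4ccccc43)c2cc1NC(=O)/C=C/CN(C)C` gives 2190 nM
compound 3 `COc1cc2ncnc(N3CCc4ccccc43)c2cc1NC(=O)/C=C/CN1CCCC1` gives 2620 nM

On these numbers compound 3 stands second highest of the three: its nearest neighbour is compound 2, a difference that lies within the scatter, and its furthest is compound 1, a difference that lies beyond it. The step to the unmeasured compound 4 `COc1cc2ncnc(N3CCc4ccccc43)c2cc1NC(=O)/C=C/CN1CCN(C)CC1` is 4-methylpiperazin-1-yl in place of pyrrolidin-1-yl on a saturated chain carbon bound to a double-bonded chain carbon.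

Within the data shown here, two measured steps bear on this. The steps of a 2.7-fold lower number from compound 1 to compound 2 (0.43 log units; beyond the scatter) and a 2.3-fold lower number from compound 1 to compound 3 (0.36 log units; beyond the scatter) show that attaching a tertiary amine to the chain lowers the number modestly, while the step of a 1.2-fold higher number from compound 2 to compound 3 (0.08 log units; within the scatter) shows that exchanging one such amine for another changes nothing beyond the scatter. Compound 4 keeps a tertiary amine at the same place, so the expected step of a 1.0-fold lower number from compound 3 to compound 4 (0.02 log units; within the scatter) is none beyond the scatter. Compound 4 is therefore estimated at 2500 nM in this assay, with a range of 1200 nM to 5200 nM.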

Compound 4, half-maximal inhibitory concentration: 9180 nM
Estimate against measurement, compound 4: 3.7-fold (0.56 log units) below; the measured number lies above the stated range.
By their numbers in this assay, from the lowest: compounds 2 and 3 (each within the scatter of the next); then compounds 1 and 4 (each within the scatter of the next).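

In this assay the earlier steps had shown one tertiary amine exchanged for another with no change beyond the scatter, but at this saturated chain carbon the exchange can matter: 4-methylpiperazin-1-yl gives a higher number against both other amines (a 3.5-fold higher number from compound 3 to compound 4 (0.54 log units; beyond the scatter); a 4.2-fold higher number from compound 2 to compound 4 (0.62 log units; beyond the scatter)). The modest gain from attaching an amine-bearing chain in place of vinyl therefore does not hold for every amine, since 3-(4-methylpiperazin-1-yl)prop-1-en-1-yl goes against that pattern (a 1.5-fold higher number from compound 1 to compound 4 (0.19 log units; within the scatter)). Nothing available here accounts for this difference.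

The compounds shown leave open whether the step follows the six-membered ring, the second ring nitrogen or its methyl group. Piperidin-1-yl, morpholin-4-yl or piperazin-1-yl at the same place would help to separate these.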